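A few compounds are considered here, and "the series" means these few. Any claim that something is new, unique, unknown or untested is made for them only; others in the source may bear on it.

In a functional assay on SK-MEL-28 cells (Homo sapiens) for inhibition (on this read-out higher numbers stand for weaker inhibition and lower numbers for stronger inhibition), compound 1 `COCCOc1cc(/C=C/c2ccc3ccccc3c2)ccc1OC` gives 2990 nM. Compound 2 `COCCOc1cc(/C=C\c2ccc3ccccc3c2)ccc1OC` gives 2990 nM, so the two stand level at the digits reported. Compound 3 `CC(=O)Oc1ccc(/C=C/c2ccc3ccccc3c2)cc1` is recorded as > 5000 nM, which is a limit and not a number.

Compound 4 `COc1ccc(/C=C/c2ccc3ccccc3c2)cc1F` has not yet been measured. It departs from compound 1 at one place: fluoro in place of 2-methoxyethoxy on an aromatic carbon. This puts fluoro in place of 2-methoxyethoxy on an aromatic carbon, ortho to a methoxy group and meta to a large group.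

For the measured compounds named here, the one measured step shows no change at the digits printed from compound 1 to compound 2 (within the scatter), and it concerns (the fact that compounds 1 and 2 differ only in the configuration as drawn). Going by the values given here, it therefore gives no direct measure of a swap at this aromatic carbon, and no measured step covers that swap. With no measured size to carry over, the expectation starts from compound 1 at 2990 nM and assumes no shift beyond the scatter, in either direction, while allowing a wide margin. Compound 4 may also be reported only as a limit. The expected change is a 1.0-fold higher number from compound 1 to compound 4 (0.00 log units; within the scatter). For compound 4 the estimated value is 3000 nM, with an expected range from 1000 nM to 8000 nM.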

Compound 4, half-maximal inhibitory concentration: > 5000 nM
Compound 4 gave a limit, no number; the forecaster's own chance of this, stated with the estimate: 30%; middle value at least 1.6-fold (0.22 log units) away from the limit.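

For the compounds shown here, replacing 2-methoxyethoxy with fluoro on this aromatic carbon, ortho to a methoxy group and meta to a large group, gives the first measured reading of a change at this position in this assay, with an at least 1.6-fold higher number from compound 1 to compound 4 (0.22 log units; that floor lies within the scatter). The swap therefore brings no lower number, but since the floor of the step lies within the scatter, the result does not establish that inhibition is weaker without the 2-methoxyethoxy group. In this assay compound 4 is recorded as > 5000 nM, which is a limit and not a number, so the true size of the step cannot be read: the limit of > 5000 nM in this assay, at which 2 of the 4 values shown sit.

The compounds shown leave open whether the full 2-methoxyethoxy chain is needed at this carbon, or whether a shorter ethoxy group, a longer ether chain, a hydroxyl or an amine would give a measurable value there. On these data alone, it also remains open whether the match between the E and Z forms seen for compounds 1 and 2 would hold with fluoro at this position.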